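A Fluorosulfonyl Group Placed on a Second Distal Ring

This account rests on a few compounds, and the source may have more. Where it says the series, first, only, none or still open, it means among the compounds named here.

Compound 1 `CC1(C)N=C(N)N=C(N)N1c1ccc(CCCCc2ccccc2)c(Cl)c1` gives 7.92 in an assay on isolated protein for inhibition of Dihydrofolate reductase (Mus musculus); on this read-out lower numbers stand for lower potency and higher numbers for higher potency (the scale is a negative logarithm). Compound 2 `CC1(C)N=C(N)N=C(N)N1c1ccc(CCCCc2ccccc2S(=O)(=O)F)c(Cl)c1` gives 7.77 in this assay; it differs from compound 1 by fluorosulfonyl in place of hydrogen on an aromatic carbon, and that step was a number 0.15 log units lower from compound 1 to compound 2 (within the scatter). Compound 3 `CC1(C)N=C(N)N=C(N)N1c1ccc(CCc2ccccc2)cc1` gives 7.89 in this assay; how its core differs from the core of compound 1 is not broken down here. Compound 4 `CC1(C)N=C(N)N=C(N)N1c1ccc(CCc2ccc(S(=O)(=O)F)cc2)cc1` carries the same kind of change, (fluorosulfonyl in place of hydrogen on an aromatic carbon), but the place is not identical: in compound 2 the group sits ortho to a large group, whereas in compound 4 it sits para to a large group. Because the step of a number 0.15 log units lower from compound 1 to compound 2 (within the scatter) lay within the scatter, compound 4 is expected to show a similarly small step, a number 0.09 log units lower from compound 3 to compound 4 (within the scatter). Compound 4 is therefore estimated at 7.8, with a likely range from 7.35 to 8.25.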

Compound 4, logarithm of the reciprocal of the active concentration, log(1/C): 7.41
Compound 4: the middle estimate sits 0.39 log units above what was measured; the measured number falls inside the stated range.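

In this assay, the fluorosulfonyl group in place of hydrogen gave a number 0.48 log units lower from compound 3 to compound 4 (beyond the scatter). Going by these compounds alone, although this step is beyond the scatter and the earlier one is not, the two cannot be told apart: the same change on two cores in this assay, a number 0.15 log units lower (within the scatter) from compound 1 to compound 2 and a number 0.48 log units lower (beyond the scatter) from compound 3 to compound 4, 0.33 log units apart, within the scatter of two such steps So far, the change carries from one core to the other without a measurable difference, but two pairs do not show that the step is constant, and since the group's place also differs between them, the effects of core and place remain unseparated.

From the compounds shown here alone, it remains open what a sulfonamide or a carboxylic acid would do in place of the fluorosulfonyl group. Also open, going by these compounds, is the step on the core of compound 1 with the group para to a large group.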